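The source may hold more compounds than are shown below. What is called first, only, known or untested is meant among the compounds shown, and "the series" means these compounds.

Working notes on the series. Compound 1 `C#CC1=CC[C@@]2(C)C(=C)CCC[C@]2(C)CC1` in a functional assay on HeLa cells (Homo sapiens) for cytotoxicity, read by MTT assay, with a stated time of 48 h (on this read-out higher numbers stand for weaker inhibition and lower numbers for stronger inhibition), gives 158000 nM. Going by the values given here, compound 2 `C=C1CCC[C@]2(C)CCC(c3cn(-c4ccc(OC)cc4)nn3)=CC[C@@]12C` in this assay gives 43600 nM, the lowest of the two numbers so far, with compound 1 standing beyond the scatter above it. The next entry is compound 3 `C=C1CCC[C@]2(C)CCC(c3cn(-c4ccc(Cl)cc4)nn3)=CC[C@@]12C`, which differs from compound 2 by chloro in place of methoxy on an aromatic carbon. Among the compounds with values here, no measured pair shows this change, so its size is unknown here. A shift within or near the scatter is expected, a 1.2-fold lower number from compound 2 to compound 3 (0.10 log units; within the scatter), with no firm direction. For compound 3 the estimate in this assay is 35000 nM, ranging from 12000 nM to 100000 nM.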

Compound 3, half-maximal inhibitory concentration: 18800 nM
Beside the measured number, compound 3's estimate is 1.9-fold (0.27 log units) above it, and the stated range covers the measured number.
By their numbers in this assay, from the lowest: compound 3; then compound 2; then compound 1.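

Going from 4-methoxyphenyl to 4-chlorophenyl gives a 2.3-fold lower number from compound 2 to compound 3 (0.37 log units; beyond the scatter) in this assay and is the first measured sign that the number responds to the group on this aromatic carbon. The step is modest and rests on this single pair. Nothing available here accounts for the shift.

From the compounds shown here alone, whether an amine or a carboxylic acid on the same aromatic carbon would move the number further remains open. So does whether chloro in place of methoxy gives a step of similar size on any other core.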